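Working notes on three measured analogues and one pending

This account rests on a few compounds, and the source may have more. Where it says the series, first, only, none or still open, it means among the compounds named here.

Measured in a functional assay on A549 cells (Homo sapiens) for antiproliferative activity, read by MTT assay, with a stated time of 48 h; a higher number here means a weaker inhibitor, a lower number a stronger inhibitor:
compound 1 `Clc1ccc(-c2nn(-c3ccccc3)cc2-c2nc3ccccc3[nH]2)cc1` gives 5960 nM
compound 2 `Cc1ccc2[nH]c(-c3cn(-c4ccccc4)nc3-c3ccc(Cl)cc3)nc2c1` gives 4640 nM
compound 3 `COc1ccc(-c2nn(-c3ccccc3)cc2-c2nc3cc(C)ccc3[nH]2)cc1` gives 5070 nM

The three measured values lie close together. The change from compound 1 to compound 2 is methyl in place of hydrogen on an aromatic carbon; it gave a 1.3-fold lower number from compound 1 to compound 2 (0.11 log units; within the scatter). The change from compound 2 to compound 3 gave a 1.1-fold higher number from compound 2 to compound 3 (0.04 log units; within the scatter). The difference between the cores of compound 1 and compound 3 is not broken down here.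

Compound 4 `COc1ccc(-c2nn(-c3ccccc3)cc2-c2nc3cc(C)c(C)cc3[nH]2)cc1` is not yet measured. It differs from compound 3 by methyl in place of hydrogen on an aromatic carbon. This is the same kind of change as that from compound 1 to compound 2, but the surroundings differ: in compound 4 the entering methyl sits ortho to a methyl group, whereas in compound 2 no such neighbour is stated. Because a 1.3-fold lower number from compound 1 to compound 2 (0.11 log units; within the scatter) stayed within the scatter, the step from compound 3 to compound 4 is expected to be small as well, about a 1.1-fold lower number from compound 3 to compound 4 (0.05 log units; within the scatter). Compound 4 is therefore estimated at 4500 nM, with a likely range from 2500 nM to 9000 nM.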

Compound 4, half-maximal inhibitory concentration: 5850 nM
The estimate for compound 4 lay 1.3-fold (0.11 log units) below the measured number, within the range that was stated.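

In this assay, methyl in place of hydrogen on an aromatic carbon gave a 1.2-fold higher number from compound 3 to compound 4 (0.06 log units; within the scatter), a step as small as the earlier one on the other core. The two steps cannot be told apart: the same change on two cores in this assay, a 1.3-fold lower number (0.11 log units; within the scatter) from compound 1 to compound 2 and a 1.2-fold higher number (0.06 log units; within the scatter) from compound 3 to compound 4, 1.5-fold (0.17 log units) apart, within the scatter of two such steps. This shows that on these two cores the change stays within the scatter, including where the entering methyl sits ortho to a methyl group, but it gives the change no reliable direction and does not show that the same result would hold on any other core.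

The compounds shown leave open whether a group other than methyl at this place, such as an amine, a carboxylic acid or a longer chain, would shift the number beyond the scatter. They also leave open whether chloro and methoxy would remain within the scatter of each other on the core of compound 4.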